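Swapping an aromatic chain end for a plain alkyl tail

The source may report more compounds than this note shows. Statements on the series, on what has been measured and on what is new or still open speak of the compounds shown alone.

Among the compounds with values here, in a functional assay on cells (T-cell line, Homo sapiens) for inhibition (a higher number here means a weaker inhibitor, a lower number a stronger inhibitor), compound 3 `COc1ccccc1CCCN1CCC(COC(c2ccccc2)c2ccccc2)CC1` gives 2400 nM and stands second highest of the three numbers measured so far. Compound 1 `COc1ccc(CCCN2CCC(COCC3CCCCC3)CC2)cc1` at 3000 nM lies within the usual scatter of compound 3, while compound 2 `COc1ccc(CCCN2CCC(COC(c3ccc(Cl)cc3)c3ccc(Cl)cc3)CC2)cc1` at 1100 nM shows a lower number, beyond the scatter.

Compound 4 `CCCCCCCN1CCC(COC(c2ccccc2)c2ccccc2)CC1` carries butyl in place of 2-methoxyphenyl on a saturated chain carbon, three bonds along the chain from an amine nitrogen in a ring. Within the data shown here, no two measured compounds differ in one place only, so the data offer no direct guide to this change. The measured numbers do stay close together, running only from compound 2 (1100 nM) to compound 1 (3000 nM). In this assay the estimated step of a 1.3-fold higher number from compound 3 to compound 4 (0.10 log units; within the scatter) is small and toward a higher number, likely within the scatter. The expected value for compound 4 is 3000 nM (estimated range 1000 nM to 9000 nM).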

Compound 4, half-maximal inhibitory concentration: 500 nM
Beside the measured number, compound 4's estimate is 6.0-fold (0.78 log units) above it; the whole stated range lies above it.
By their numbers in this assay, from the lowest: compound 4; then compound 2; then compounds 3 and 1 (each within the scatter of the next).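

In this assay, within the data shown here, the change from 2-methoxyphenyl to butyl, on a saturated chain carbon, three bonds along the chain from an amine nitrogen in a ring, gives a 4.8-fold lower number from compound 3 to compound 4 (0.68 log units; beyond the scatter) and so gives the first comparison here of two compounds that differ in one place. The aromatic ring and the hydrogen-bond acceptor of 2-methoxyphenyl are therefore not required at this position for this level of inhibition, since butyl has neither and carries fewer heavy atoms. No supporting measurement accounts for the lower number.

Going by these compounds, the step rests on a single pair, so it remains open whether butyl would act the same way on compound 1 or compound 2. Also open, on these data alone, is how a longer alkyl chain, or a chain ending in an amine or a carboxylic acid, would compare with butyl.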